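Trimming an amide: what compound 4 should show

The source may hold more compounds than are shown below. What is called first, only, known or untested is meant among the compounds shown, and "the series" means these compounds.

The shared core carries a side chain ending in an amide, and the piece asks what happens when that amide is stripped of its two substituents. In a functional assay on the whole organism with Mus musculus as the target (a lower number here means that less compound is needed, a higher number that more compound is needed for the effect), compound 1, with structure `CN(C)C(=O)/C=C1\CCc2ccc(F)cc21`, gives only a limit of the assay, > 100 mg/kg, and no number. That value is the limit of > 100 mg/kg in this assay, at which 2 of the 3 values shown sit, so compound 1 stands at the edge of what the measurement can report.

The measured pair that speaks to this change sits in a related series. Compound 2, structure `Cc1cccc2c1CC/C2=C\C(=O)NC1CC1`, gives 40 mg/kg in this assay. Compound 3, structure `Cc1cccc2c1CC/C2=C\C(N)=O`, gives only a limit of the assay, > 100 mg/kg. The step between them, an at least 2.5-fold higher number from compound 2 to compound 3 (0.39 log units; beyond the scatter), shows that replacing a substituent on the amide nitrogen by hydrogen made a higher dose necessary, beyond the scatter.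

Compound 4, structure `NC(=O)/C=C1\CCc2ccc(F)cc21`, differs from compound 1 by amino in place of dimethylamino on a carbonyl carbon. This is the same kind of trimming of the amide, and compound 1 already sits at the limit. The step expected here is a step that the limit leaves unreadable from compound 1 to compound 4, most likely no measurable number at all. Compound 4 is therefore expected to give 200 mg/kg, within a range from 70 mg/kg to 600 mg/kg, and most probably again only a limit of the assay.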

Compound 4, dose for half-maximal effect: 56 mg/kg
Compound 4: middle estimate off by 3.6-fold (0.55 log units), on the high side; measured number outside the range, below it.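

Going from dimethylamino to amino on the carbonyl carbon gives an at least 1.7-fold lower number from compound 1 to compound 4 (0.25 log units; that floor lies within the scatter), which points the opposite way to the earlier trimming, an at least 2.5-fold higher number from compound 2 to compound 3 (0.39 log units; beyond the scatter). An amide nitrogen carrying only hydrogens therefore does not always call for a higher dose in this assay: the direction differs between these two pairs, which differ both in their cores and in the group that leaves. The true size of the new step stays unknown, and its floor lies within the scatter, because one end of the step is not a number: the limit of > 100 mg/kg in this assay, at which 2 of the 4 values shown sit.

Going by these compounds, whether a single methyl on the amide nitrogen, giving methylamino on the carbonyl carbon, behaves like amino or like dimethylamino on the core of compound 1 remains open. Also open is what a carboxylic acid would do in place of the amide on this core, or the cyclopropylamino group, which in the related series belongs to compound 2 at 40 mg/kg.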